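A methyl step on compound 2

A few compounds are considered here, and "the series" means these few. Any claim that something is new, unique, unknown or untested is made for them only; others in the source may bear on it.

- compound 1 `Cc1ccc2c(O)cc(-c3cccc(Cl)c3)nc2n1`: 170 nM
- compound 2 `Oc1cc(-c2ccc3ccccc3c2)nc2ncccc12`: 8130 nM
- compound 3 `Cc1cc(C)c2c(O)cc(-c3cccc(Cl)c3)nc2n1`: 347 nM

In a functional assay on cells (Tumor Cell line, Homo sapiens) for antiproliferative activity (a lower number here means a stronger inhibitor of growth, a higher number a weaker inhibitor of growth), compound 2 stands highest of the three at 8130 nM, well above compound 3 and further still above compound 1, so it is the weakest inhibitor of growth among them. The change followed here leads from compound 2 to compound 4 `Cc1ccnc2nc(-c3ccc4ccccc4c3)cc(O)c12`: methyl in place of hydrogen on an aromatic carbon. In words, this is methyl in place of hydrogen on an aromatic carbon, opposite the ring nitrogen.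

For the measured compounds named here, only one measured step bears on it. The same replacement, also opposite the ring nitrogen, gives a 2.0-fold higher number from compound 1 to compound 3 (0.31 log units; beyond the scatter). That step is modest, and it stands alone. It was also measured on compounds that carry a different group on the shared core, and compound 1 already holds another methyl. It therefore points towards a small rise in the number at most, and it is weak evidence for carrying that rise over to compound 2. The step expected is a 1.1-fold higher number from compound 2 to compound 4 (0.04 log units; within the scatter), so no change beyond the scatter is anticipated. The estimate for compound 4 is 9000 nM, with an expected range of 2500 nM to 30000 nM.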

Compound 4, concentration for 50% growth inhibition: 1200 nM
Compound 4: the middle estimate sits 7.5-fold (0.88 log units) above what was measured; measured number outside the range, below it.
By their numbers in this assay, from the lowest: compound 1; then compound 3; then compound 4; then compound 2.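

In this assay, for the compounds shown here, methyl in place of hydrogen on an aromatic carbon, opposite the ring nitrogen, turns out to have no single direction: here it gives a 6.8-fold lower number from compound 2 to compound 4 (0.83 log units; beyond the scatter), whereas the only earlier step had pointed the other way. The position is therefore not one where this methyl simply costs a little growth inhibition, and the size and sign of the change depend on the compound that carries it, as the two steps show: the same change on two cores in this assay, a 2.0-fold higher number (0.31 log units; beyond the scatter) from compound 1 to compound 3 and a 6.8-fold lower number (0.83 log units; beyond the scatter) from compound 2 to compound 4, 14-fold (1.14 log units) apart, beyond the scatter of two such steps The two pairs differ both in the group carried on the shared core and in the further methyl that compound 1 already holds, so these steps cannot say which of the two differences goes with the reversal.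

On these data alone, whether an ethyl group, a methoxy group or an amine in this same position would follow the gain seen with methyl in compound 4 remains open. Also open, as far as these compounds go, is how the methyl step would read on the core of compound 2 with the further methyl of compound 1 added, which would separate the two differences.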